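The source may hold more compounds than are shown below. What is called first, only, known or untested is meant among the compounds shown, and "the series" means these compounds.

Within the data shown here, compound 1 `Cc1cccc(C(=O)/C=C/c2ccncc2)c1` is one of two compounds measured in a functional assay with Rattus norvegicus as the target; a higher number here means a weaker inhibitor, a lower number a stronger inhibitor. Compound 1 gives 39000 nM, the lower of the two numbers, while compound 2 `O=C(/C=C/c1ccncc1)c1ccc(C(F)(F)F)cc1` gives 204000 nM, a gap beyond the usual scatter. Compound 3 `N#Cc1cccc(C(=O)/C=C/c2ccncc2)c1` has not yet been measured. Compared with compound 1 it differs in one place: cyano in place of methyl on an aromatic carbon. Among the measured compounds shown here, no measured pair shows such a swap, so only a small shift is expected, probably none beyond the scatter. The step expected in this assay is a 1.3-fold higher number from compound 1 to compound 3 (0.11 log units; within the scatter). Compound 3 is therefore estimated at 50000 nM, with a range from 15000 nM to 160000 nM.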

Compound 3, half-maximal inhibitory concentration: 85000 nM
Estimate against measurement, compound 3: 1.7-fold (0.23 log units) below, within the range that was stated.
By their numbers in this assay, from the lowest: compound 1; then compound 3; then compound 2.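

Swapping methyl for cyano on this aromatic carbon, meta to a large group, gives a 2.2-fold higher number from compound 1 to compound 3 (0.34 log units; beyond the scatter) in this assay. Among these compounds, this is the first measured change at a single place, and it shows that the position responds to the swap, though only modestly, with cyano giving the weaker inhibitor. Nothing available explains why the number rises.

Going by these compounds, how an amine or a carboxylic acid would behave on this same carbon remains open. A single swap cannot show how other groups at this position would rank.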